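Two coumarin-lipoamide hybrids and an ester variant

This account rests on a few compounds, and the source may have more. Where it says the series, first, only, none or still open, it means among the compounds named here.

Compound 2 `CC(=O)c1cc2ccc(OCCCn3cc(CNC(=O)CCCCC4CCSS4)nn3)cc2oc1=O` and compound 1 `O=C(CCCCC1CCSS1)NCc1cn(CCCOc2ccc3ccc(=O)oc3c2)nn1` share a common core and were both tested in a functional assay on PC-12 cells (Rattus norvegicus) for cytotoxicity, read by MTT assay, with stated times of 3 h and 2 h, tested at 5 uM; on this read-out higher numbers stand for a stronger effect at the one concentration tested and lower numbers for a weaker effect. In this assay compound 1 gives 39.2%, and compound 2 gives 37.5%. Among the compounds with values here, the two numbers sit close together: the change a number 1.7 percentage points lower from compound 1 to compound 2 (within the scatter) is the only measured step, and it places compound 2 as the lower of two values only in a way that the scatter does not distinguish.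

Compound 3 `CCOC(=O)c1cc2ccc(OCCCn3cc(CNC(=O)CCCCC4CCSS4)nn3)cc2oc1=O` differs from compound 2 by ethoxy in place of methyl on a carbonyl carbon. Within the data shown here, no measured step touches this exact change, and the one step that does exist, where acetyl replaced hydrogen, stayed within the scatter. There is therefore no ground to expect a shift beyond the scatter in this assay.

Compound 3 is expected to give about 37%, with a range from 27% to 47%. The expected step of a number 0.5 percentage points lower from compound 2 to compound 3 (within the scatter) is accordingly estimated to be small.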

Compound 3, a percentage reported as activity, at one concentration (the size of the read-out at that concentration, not a potency): 32.4%
Beside the measured number, compound 3's estimate is 4.6 percentage points above it; low and high end bracket the measured number.
By their numbers in this assay, from the lowest: compounds 3, 2 and 1 (each within the scatter of the next).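

In this assay, ethoxycarbonyl on this aromatic carbon gives a number 6.8 percentage points lower from compound 1 to compound 3 (within the scatter) when it takes the place of hydrogen, and a number 5.1 percentage points lower from compound 2 to compound 3 (within the scatter) when ethoxy takes the place of methyl on the carbonyl carbon. A second carbonyl-bearing group at this position therefore also stays inside the usual scatter of repeated measurements, so hydrogen, acetyl and ethoxycarbonyl cannot be told apart here. No accompanying measurement bears on what lies behind these small differences.

On these data alone, both groups tried on this carbon so far carry a carbonyl, so it remains open whether a carboxylic acid, an amide or a simple amine would move the read-out beyond the scatter. As far as these compounds go, a longer chain on the ester oxygen, such as butoxy in place of ethoxy, is equally open.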